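This account rests on a few compounds, and the source may have more. Where it says the series, first, only, none or still open, it means among the compounds named here.

Compound 1, `O=C(Nc1cccc(S(=O)(=O)N2CCCC2)c1)c1cccnc1N1CCC2(CC1)CC2`, in an ADME assay on microsomes from liver (Mus musculus) for metabolic stability, read by LC-MS, with a stated time of 40 min, tested at 0.5 uM (on this read-out higher numbers stand for fast clearance and lower numbers for slow clearance), gives > 399 mL.min-1.g-1, which is a limit of the assay and not a number.
Compound 2, `CC(C)(C)NS(=O)(=O)c1cccc(NC(=O)c2cccnc2N2CCC3(CC2)CC3)c1`, in this assay gives > 399 mL.min-1.g-1, likewise a limit of the assay.

Compound 2 thus stands at the upper limit, as does compound 1, so that (the limit of > 399 mL.min-1.g-1 in this assay, at which 2 of the 2 values shown sit). Within the data shown here, the only measured step, a step that the two limits leave unreadable from compound 1 to compound 2, is therefore not readable in size. Compound 3, `O=C(Nc1cccc(S(=O)(=O)C2COC2)c1)c1cccnc1N1CCC2(CC1)CC2`, differs from compound 2 by oxetan-3-yl in place of (tert-butyl)amino on a sulfonyl sulfur. No readable measured step bears on this change, and compound 2 at the limit leaves the step of an at least 1.1-fold lower number from compound 2 to compound 3 (0.05 log units; that floor lies within the scatter) expected to be small or unreadable. Compound 3 is estimated at 350 mL.min-1.g-1, within a range of 120 mL.min-1.g-1 to 900 mL.min-1.g-1.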

Compound 3, intrinsic clearance in microsomes: 385 mL.min-1.g-1
Beside the measured number, compound 3's estimate is 1.1-fold (0.04 log units) below it; measured number inside the range.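

With oxetan-3-yl on the sulfonyl sulfur, compound 3 is the first compound in this assay to return a number, whereas compound 1 and compound 2 stay at a limit of the assay: the limit of > 399 mL.min-1.g-1 in this assay, at which 2 of the 3 values shown sit.

On these data alone, the change yields only floors, an at least 1.0-fold lower number from compound 2 to compound 3 (0.01 log units; that floor lies within the scatter) and an at least 1.0-fold lower number from compound 1 to compound 3 (0.01 log units; that floor lies within the scatter), so neither step shows that it lowers clearance, and the true size of both stays unknown.

As far as these compounds go, what stays open is how the read-out moves with other groups on a sulfonyl sulfur, such as morpholin-4-yl or methyl, and whether any of them gives a number well clear of the limit.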